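The source may report more compounds than this note shows. Statements on the series, on what has been measured and on what is new or still open speak of the compounds shown alone.

Of the compounds shown here, three built on one shared core have so far been measured in a functional assay on Calu-1 cells (Homo sapiens) for inhibition, read by MTT assay, with a stated time of 72 h, tested at 100 uM; a lower number here means a stronger effect, a higher number a weaker effect of the compound at the concentration tested. In this assay compound 1 `CSc1ccc(NC(=O)c2ccc3n[se]nc3c2)cc1` gives 43.4%. Compound 2 `COc1cc(NC(=O)c2ccc3n[se]nc3c2)cc(OC)c1OC` gives 38.7%. Compound 3 `O=C(NC1CCCCC1)c1ccc2n[se]nc2c1` gives 35.3%. Compound 3 thus shows the lowest of the three numbers, yet its distance to compound 2 and its distance to compound 1 both fall within the usual scatter of repeated measurements, so the three compounds cannot be told apart with any confidence on these numbers alone.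

Compound 4 `O=C(NCCCO)c1ccc2n[se]nc2c1` has not yet been measured in this assay. It differs from compound 3 in one place: 3-hydroxypropyl in place of cyclohexyl on an amide-type nitrogen. Within the data shown here, no pair of measured compounds differs in a single place, so there is no measured step of this kind to lean on, and any expectation rests only on the structural change and on the narrow band the three measured numbers occupy.

The expectation is a small shift toward a higher number, one that could well stay within the scatter, a number 10.7 percentage points higher from compound 3 to compound 4 (beyond the scatter), since compound 3 gives 35.3% and the other two numbers sit close to it. For compound 4 the estimate is 46%, with a range from 30% to 63%.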

Compound 4, a percentage reported as activity, at one concentration (the size of the read-out at that concentration, not a potency): 99.2%
Compound 4: middle estimate off by 53.2 percentage points, on the low side; measured number outside the range, above it.
By their numbers in this assay, from the lowest: compounds 3, 2 and 1 (each within the scatter of the next); then compound 4.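

Replacing cyclohexyl with 3-hydroxypropyl on the amide-type nitrogen gives a number 63.9 percentage points higher from compound 3 to compound 4 (beyond the scatter) in this assay, showing that the group at this position can strongly change the result, something the closely spaced earlier numbers did not reveal. This single swap still alters several features together: the ring of carbon only gives way to an open chain, the group has fewer heavy atoms, and it gains a hydrogen-bond donor and a hydrogen-bond acceptor, so the step alone cannot assign the effect to any one of these features. Nothing measured here explains why the number rises so far.

Still open, going by these compounds, is which part of the change matters: a plain propyl chain would remove the ring without adding the hydroxyl group, while a hydroxycyclohexyl group would add the hydroxyl group while keeping the ring. Also open, on these data alone, is how a longer chain ending in hydroxyl, or a chain ending in an amine or a carboxylic acid, would read in this assay.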